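Aryl versus cyclopentyl on the amine nitrogen of the core

The source may report more compounds than this note shows. Statements on the series, on what has been measured and on what is new or still open speak of the compounds shown alone.

Three compounds of the series have numbers in a functional assay on MCF7 cells (Homo sapiens) for inhibition, read by sulforhodamine B assay; a higher number here means a weaker inhibitor, a lower number a stronger inhibitor. Compound 1, `O=C1C=C(Nc2ccc(I)cc2)C(=O)c2c1nc1n2[C@H]2OC[C@@H](O)[C@H]2OC1`, gives 2230 nM. Compound 2, `O=C1C=C(Nc2ccccc2)C(=O)c2c1nc1n2[C@H]2OC[C@@H](O)[C@H]2OC1`, reaches only a limit of the assay, > 4000 nM. Compound 3, `O=C1C=C(NC2CCCC2)C(=O)c2c1nc1n2[C@H]2OC[C@@H](O)[C@H]2OC1`, likewise reaches only a limit of the assay, > 16000 nM, and so stands at the weak end of what the numbers show; this is recorded as the limit of > 16000 nM in this assay, at which 1 of the 3 values shown sits. Of the steps, an at least 1.7-fold higher number from compound 1 to compound 2 (0.25 log units; that floor lies within the scatter), an at least 7.1-fold higher number from compound 1 to compound 3 (0.85 log units; beyond the scatter), and a step that the two limits leave unreadable from compound 2 to compound 3, the last because both ends sit at limits, the limit of > 4000 nM in this assay, at which 1 of the 3 values shown sits, and (the limit of > 16000 nM in this assay, at which 1 of the 3 values shown sits).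

Compound 4, `CCOc1ccccc1NC1=CC(=O)c2nc3n(c2C1=O)[C@H]1OC[C@@H](O)[C@H]1OC3`, is not yet measured. It differs from compound 3 by 2-ethoxyphenyl in place of cyclopentyl on an amine nitrogen. The step that bears on it is the one in the opposite direction, from a 4-iodophenyl on that nitrogen to cyclopentyl, which raised the number by the size of an at least 7.1-fold higher number from compound 1 to compound 3 (0.85 log units; beyond the scatter); restoring an aryl group is therefore expected to lower the number, by a step of an at least 3.2-fold lower number from compound 3 to compound 4 (0.50 log units; beyond the scatter) in this assay, though compound 2 shows that a phenyl without iodo also ended at a limit. Compound 4 is estimated at 5000 nM, between 1500 nM and 16000 nM.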

Compound 4, half-maximal inhibitory concentration: > 4000 nM
Compound 4 gave a limit, no number (the forecaster's own chance of this, stated with the estimate: 40%); the middle value does not contradict the limit.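

In this assay compound 4 is recorded only as a limit, > 4000 nM. Going by these compounds alone, the change from 4-iodophenyl to 2-ethoxyphenyl on the amine nitrogen gives an at least 1.7-fold higher number from compound 1 to compound 4 (0.25 log units; that floor lies within the scatter), so no order of these two aryl groups can be stated, and compound 1 remains the only one of the four compounds with a number rather than a limit. The steps to compound 4 from compound 2 and from compound 3 cannot be read, because a limit stands at both ends of each: the limit of > 4000 nM in this assay, at which 2 of the 4 values shown sit.

Still open, on these data alone, is whether ethoxy on the phenyl ring changes the result in either direction, and whether a 2-ethoxyphenyl group on this nitrogen differs from cyclopentyl at all, since neither question can be answered from limits alone. As far as these compounds go, it is also open whether the number of compound 1 depends on iodo specifically, and a 4-bromophenyl or a 4-chlorophenyl group on the same nitrogen of the shared core would bear on that, as would a benzyl group for the need for an aryl ring directly on the nitrogen.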